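Removing One Fluoro: Cytotoxicity of a Hydroxamic Acid Series

The compounds below may be only part of what the source reports. "The series", "measured", "known", "first", "only" and "open" are said of these compounds alone.

Of the compounds shown here, three have been tested in an ADME assay on CEM-SS cells (Homo sapiens) for cytotoxicity, read by XTT assay; on this read-out higher numbers stand for lower toxicity in this test and lower numbers for higher toxicity in this test. Compound 1 is `O=C(NO)c1cc2ccn(Cc3cccc(Cl)c3F)c2cn1`, compound 2 is `O=C(NO)c1cc2ccn(Cc3c(F)ccc(Cl)c3F)c2cn1`, and compound 3 is `CN(O)C(=O)c1cc2ccn(Cc3ccc(F)cc3F)c2cn1`. For compound 1 the result is a limit of the assay, > 320000 nM. For compound 2 the result is also a limit, > 1000 nM. Among the compounds with values here, compound 3 is the only one with a number: in this assay compound 3 gives 135000 nM. The two limits are the limit of > 1000 nM in this assay, at which 1 of the 3 values shown sits, and (the limit of > 320000 nM in this assay, at which 1 of the 3 values shown sits). The step from compound 2 to compound 1, a step that the two limits leave unreadable from compound 2 to compound 1, is therefore not readable in size, although the structural change is clear: hydrogen in place of fluoro on an aromatic carbon. The difference between the cores of compound 2 and compound 3 is not broken down here.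

The compound still to be measured is compound 4, `CN(O)C(=O)c1cc2ccn(Cc3ccc(F)cc3)c2cn1`. It arises from compound 3 by hydrogen in place of fluoro on an aromatic carbon. This is the same kind of change as that from compound 2 to compound 1, but the surroundings differ: in compound 2 the fluoro that leaves is also para to a chloro group, whereas in compound 3 it is not. The step from compound 2 to compound 1 is unreadable from the two limits. The measured data give no usable size for such a change. The change is expected to make a step of a 1.1-fold higher number from compound 3 to compound 4 (0.05 log units; within the scatter). This expectation rests on compound 3 and its value of 135000 nM, taken as the anchor. Compound 4 is accordingly expected to give 150000 nM, with a range from 60000 nM to 400000 nM.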

Compound 4, half-maximal cytotoxic concentration: 200000 nM
Estimate against measurement, compound 4: 1.3-fold (0.12 log units) below; the range from low to high includes it.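

In this assay, hydrogen in place of fluoro on an aromatic carbon gives a 1.5-fold higher number from compound 3 to compound 4 (0.17 log units; within the scatter), so on the core of compound 3 this change leaves the read-out within the usual scatter of repeated measurements. The matching step on the other core, from compound 2 to compound 1, cannot be read, because compound 2 rests on a limit of the assay and not on a number: the limit of > 1000 nM in this assay, at which 1 of the 4 values shown sits. Compound 1 also rests on a limit of the assay, so the series offers only one readable instance of this change, and nothing here shows whether the small step seen on the core of compound 3 carries over to the core of compound 1, or whether it does not: the limit of > 320000 nM in this assay, at which 1 of the 4 values shown sits.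

The compounds shown leave open how the read-out would respond on either core if an amine or a methoxy group took the place of the fluoro, rather than hydrogen. They also leave open what a carboxylic acid in place of the hydroxamic acid would give, and whether the result would hold with a longer chain in place of the single carbon that joins the halogenated ring to the core.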